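Replacing Benzyloxy in a Series Without a Baseline

The source may hold more compounds than are shown below. What is called first, only, known or untested is meant among the compounds shown, and "the series" means these compounds.

compound 1 `CS(=O)(=O)Nc1ccc(-n2cc(COc3ccccc3Cl)nn2)cc1Oc1ccccc1`: 53800 nM
compound 2 `CS(=O)(=O)Nc1ccc(-n2cc(-c3ccccc3)nn2)cc1Oc1ccccc1`: 29900 nM
compound 3 `CS(=O)(=O)Nc1ccc(-n2cc(OCc3ccccc3)nn2)cc1Oc1ccccc1`: "not determined" (no result reported)

The three compounds share one core and were examined in a functional assay on A549 cells (Homo sapiens) for inhibition, read by MTT assay, with a stated time of 48 h; a higher number here means a weaker inhibitor, a lower number a stronger inhibitor. Compound 1 gives 53800 nM and compound 2 gives 29900 nM. Compound 3 stands at "not determined" (no result reported), so it offers no starting value for the next step.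

That step leads to compound 4 `Cc1cc(OCc2cn(-c3ccc(NS(C)(=O)=O)c(Oc4ccccc4)c3)nn2)ccc1Cl`, which has not yet been measured. The structural change is (4-chloro-3-methylphenoxy)methyl in place of benzyloxy on an aromatic carbon. With no value for compound 3, no size or direction can be expected for this step itself.

Going by the values given here, only one measured step bears on the question, and only indirectly. It is a 1.8-fold lower number from compound 1 to compound 2 (0.26 log units; within the scatter), a replacement of (2-chlorophenoxy)methyl at the same place, and it lies within the scatter. The closest guide is therefore compound 1 at 53800 nM, which also carries a chlorinated phenoxymethyl group. Among the compounds with values here, no measured compound shows what the added methyl does, so the range must stay wide.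

For compound 4, the expected value in this assay is an estimated 40000 nM, within a range of 15000 nM to 100000 nM.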

Compound 4, half-maximal inhibitory concentration: 6700 nM
For compound 4 the middle estimate is 6.0-fold (0.78 log units) above the measured one; the measured number lies below the stated range.
By their numbers in this assay, from the lowest: compound 4; then compounds 2 and 1 (each within the scatter of the next).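

In this assay, going by these compounds alone, this position on the five-membered aromatic ring now gives a step beyond the scatter, whereas the only earlier step, between compound 1 and compound 2, lay within it. The clearest reading comes from the aryl group on the oxygen: 4-chloro-3-methylphenyl in place of 2-chlorophenyl gives an 8.0-fold lower number from compound 1 to compound 4 (0.90 log units; beyond the scatter), while the (4-chloro-3-methylphenoxy)methyl group in place of phenyl gives a 4.5-fold lower number from compound 2 to compound 4 (0.65 log units; beyond the scatter), so the two steps agree in direction and show that the identity of the aryl group matters, not merely the presence of a phenoxymethyl arm. No measurement shown here accounts for this gain.

Within the data shown here, the step from benzyloxy cannot be read, since compound 3 has no number, and the single change from 2-chlorophenyl to 4-chloro-3-methylphenyl does not separate the added methyl from the different placing of the chlorine. From the compounds shown here alone, it also remains open how this position would respond to an amine or a carboxylic acid on the outer ring, or to an ethyl group in place of the methyl.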